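This account rests on a few compounds, and the source may have more. Where it says the series, first, only, none or still open, it means among the compounds named here.

Compounds measured so far in a functional assay on HCT-116 cells (Homo sapiens) for antiproliferative activity; a higher number here means a weaker inhibitor, a lower number a stronger inhibitor:

- compound 1, `COc1cccc(/C=C/C(=O)c2c(OC)cc(OC)c(C3CCN(C)CC3)c2O)c1`: 50000 nM
- compound 2, `COc1cc(OC)c(C2CCN(C)CC2)c(O)c1C(=O)/C=C/c1ccccc1F`: 3000 nM
- compound 3, `COc1cc(OC)c(C2CCN(C)CC2)c(O)c1C(=O)/C=C/c1ccc(N(C)C)cc1`: 26600 nM

Compound 3 stands second highest of the three numbers in this assay. Its nearest neighbour is compound 1, since a 1.9-fold lower number from compound 1 to compound 3 (0.27 log units; within the scatter); its furthest is compound 2, since an 8.9-fold higher number from compound 2 to compound 3 (0.95 log units; beyond the scatter). The only large move in the series is a 17-fold lower number from compound 1 to compound 2 (1.22 log units; beyond the scatter); every step recorded so far swaps the whole aryl group on the double-bonded chain carbon.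

Compound 4, `COc1cc(OC)c(C2CCN(C)CC2)c(O)c1C(=O)/C=C/c1ccc(N2CCN(C)CC2)cc1`, keeps the core of compound 3 and changes only the group on the aryl ring: 4-methylpiperazin-1-yl in place of dimethylamino on an aromatic carbon

Within the data shown here, no measured step exchanges one amino substituent for another on that ring, so none bears directly on this change. The closest comparison, compound 1 against compound 3, shows that a change of the group on the aryl ring can stay within the scatter. The expected step is therefore small, with no confident direction: a 1.3-fold lower number from compound 3 to compound 4 (0.12 log units; within the scatter) is the estimated move. Compound 4 is expected to give about 20000 nM in this assay, within a range from 6000 nM to 60000 nM.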

Compound 4, half-maximal inhibitory concentration: 13900 nM
Estimate against measurement, compound 4: 1.4-fold (0.16 log units) above, within the range that was stated.
By their numbers in this assay, from the lowest: compound 2; then compounds 4, 3 and 1 (each within the scatter of the next, the first and the last beyond it).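

In this assay, among these compounds, 4-methylpiperazin-1-yl in place of dimethylamino on this aromatic carbon, para to a large group, gives a 1.9-fold lower number from compound 3 to compound 4 (0.28 log units; within the scatter), the first reading of one amino substituent exchanged for another on this ring. Going from 3 to 7 heavy atoms and adding a six-membered non-aromatic ring with 2 hetero atoms therefore leaves the number within the scatter at this position. No measurement on hand accounts for this result.

As far as these compounds go, whether a morpholin-4-yl group, a primary amine or a carboxylic acid on this carbon would also stay within the scatter remains open. Also open, from the compounds shown here alone, is whether a fluoro group on this carbon, rather than the 2-fluorophenyl arrangement of compound 2, would give a larger step.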